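Swapping a Benzyloxy Group for 4-Fluorophenyl

This account rests on a few compounds, and the source may have more. Where it says the series, first, only, none or still open, it means among the compounds named here.

Compound 1, `C=C[C@@](C)(/C=C/c1ccc(OCc2ccccc2)cc1)CCC=C(C)C`, was tested in a functional assay on SEM cells (Homo sapiens) for cytotoxicity, with a stated time of 72 h; a higher number here means that more compound is needed for the effect, a lower number that less compound is needed. In this assay compound 1 reaches only the limit of the measurement, giving > 36600 nM. Compound 2, `C=C[C@@](C)(/C=C/c1ccc(Nc2cc(C(F)(F)F)cc(C(F)(F)F)c2)cc1)CCC=C(C)C`, belongs to the same series. In this assay compound 2 likewise gives only a limit, > 36600 nM. Among the compounds with values here, both values rest at the limit of > 36600 nM in this assay, at which 2 of the 2 values shown sit, so neither compound carries a measured number on this scale, and no step between measured compounds can be drawn from these two points.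

Compound 3, `C=C[C@@](C)(/C=C/c1ccc(-c2ccc(F)cc2)cc1)CCC=C(C)C`, has not yet been measured. It differs from compound 1 by 4-fluorophenyl in place of benzyloxy on an aromatic carbon. Within the data shown here, with both measured compounds sitting at the same limit, there is no measured step to lean on, and a change of this kind gives no ground to expect a shift beyond the usual scatter in either direction. The step that the limit leaves unreadable from compound 1 to compound 3 is therefore expected to be close to none. For compound 3 the estimate in this assay is 40000 nM, with a range from 15000 nM to 100000 nM, and the result is expected most likely to be reported again only as a limit.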

Compound 3, half-maximal effective concentration: > 36600 nM
Compound 3: only a limit was reported; the forecaster's own chance of this, stated with the estimate: 80%; the middle value lies beyond the limit too.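

Compound 3, like compound 1, ends at a limit in this assay and not at a number, so the step from benzyloxy to 4-fluorophenyl cannot be read: the limit of > 36600 nM in this assay, at which 3 of the 3 values shown sit. The compounds shown leave open at what concentration, if any, these compounds affect the cells, and whether any change to the shared core gives a measurable value.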